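The source may report more compounds than this note shows. Statements on the series, on what has been measured and on what is new or still open speak of the compounds shown alone.

Working notes on a small set sharing one core, read in an ADME assay on HepG2 2.2.15 cells (Homo sapiens) for cytotoxicity; on this read-out lower numbers stand for higher toxicity in this test and higher numbers for lower toxicity in this test. Compound 1 `O=C(Nc1ncc(Cc2ccc(F)cc2)s1)c1ccc(Br)cc1` reports only a limit in this assay, > 50000 nM. Compound 2 `CC(C)(C)OC(=O)Nc1ncc(C(Oc2ccc(OCc3ccccc3)cc2)c2ccc(Cl)cc2)s1` likewise reports only a limit in this assay, > 50000 nM. Compound 3 `O=C(Nc1ncc(C(OCc2ccc(Cl)cc2)c2ccccc2)s1)c1cccs1` carries no figure in this assay and is recorded as "not toxic" (no number reported). Where compound 3 stands is therefore only this: two of the three entries sit at the limit of > 50000 nM in this assay, at which 2 of the 3 values shown sit, and compound 3 joins them without a number. Compound 4 `O=C(Nc1ncc(C(OCc2ccc(F)cc2Br)c2ccccc2)s1)c1cccs1` is not yet measured; it differs from compound 3 by 2-bromo-4-fluorophenyl in place of 4-chlorophenyl on a saturated chain carbon bound to an oxygen on a saturated carbon. Among the measured compounds shown here, with no measured step between two compounds to lean on, the expected step in this assay is none beyond the scatter, in either direction. The estimate for compound 4 in this assay is 50000 nM, with a range from 20000 nM to 100000 nM, and most likely only a limit will be reported.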

Compound 4, half-maximal cytotoxic concentration: "not toxic" (no number reported)
No number was reported for compound 4; there is nothing to compare the estimate with.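

Compound 3 and compound 4 are both recorded as "not toxic" without a number in this assay, so no step can be read between them. The compounds shown leave open whether any change on the shared core gives a measurable cytotoxic concentration, as the entries so far show: the limit of > 50000 nM in this assay, at which 2 of the 4 values shown sit.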